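A few compounds are considered here, and "the series" means these few. Any claim that something is new, unique, unknown or untested is made for them only; others in the source may bear on it.

In a functional assay on UO-31 cells (Homo sapiens) for inhibition, read by sulforhodamine B assay, with a stated time of 48 h (a higher number here means a weaker inhibitor of growth, a lower number a stronger inhibitor of growth), compound 1 `O=C(Cc1csc2nc(-c3ccc(Br)cc3)cn12)N/N=C/c1ccccc1` gives 57500 nM and compound 2 `O=C(Cc1csc2nc(-c3ccc(Br)cc3)cn12)N/N=C/c1ccccc1O` gives 7080 nM, the lower of the two numbers. Compound 3 `O=C(Cc1csc2nc(-c3ccc(Br)cc3)cn12)N/N=C/c1ccc(O)cc1` differs from compound 2 as follows: 4-hydroxyphenyl in place of 2-hydroxyphenyl on a carbon with a double bond to nitrogen. For the measured compounds named here, no measured step tests this change directly. The closest is an 8.1-fold lower number from compound 1 to compound 2 (0.91 log units; beyond the scatter), with hydroxy in place of hydrogen on an aromatic carbon. Compound 3 still carries a hydroxy, so only part of that gain is expected to be lost. A modest rise in the number is expected in this assay, an estimated 2.3-fold higher number from compound 2 to compound 3 (0.35 log units; beyond the scatter). The estimate for compound 3 is 16000 nM, with an expected range of 5000 nM to 50000 nM.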

Compound 3, concentration for 50% growth inhibition: 26300 nM
For compound 3 the middle estimate is 1.6-fold (0.22 log units) below the measured one; measured number inside the range.
By their numbers in this assay, from the lowest: compound 2; then compound 3; then compound 1.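

In this assay, the place of the hydroxy on the ring matters, not only its presence: 4-hydroxyphenyl in place of 2-hydroxyphenyl gives a 3.7-fold higher number from compound 2 to compound 3 (0.57 log units; beyond the scatter) in the growth-inhibition number. The 4-hydroxyphenyl group still improves on plain phenyl, with a 2.2-fold lower number from compound 1 to compound 3 (0.34 log units; beyond the scatter) as the measured gain, though this is smaller than an 8.1-fold lower number from compound 1 to compound 2 (0.91 log units; beyond the scatter) for the 2-hydroxyphenyl group. Nothing available explains why the two placements differ. Open questions are whether a methoxy or an amine in place of the hydroxy would keep this gain, and whether 2-hydroxyphenyl stays ahead of 4-hydroxyphenyl with a chlorine in place of the bromine.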